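A few compounds are considered here, and "the series" means these few. Any claim that something is new, unique, unknown or untested is made for them only; others in the source may bear on it.

Compound 2 `N=c1c2cc(-c3ccc(Cl)cc3)n(-c3ccccc3)c2[nH]c(=S)n1N` gives the lower of two numbers in a functional assay on the whole organism for inhibition, with Rattus norvegicus as the target, read by ELISA, with stated times of 30 min and 6 h, at a dose of 30 mg/kg by the oral route (a lower number here means less inhibition, a higher number more inhibition at the dose given (going by the name of the read-out)), at 0%. For the measured compounds named here, compound 1 `CCn1c(=S)[nH]c2c(cc(-c3ccc(Cl)cc3)n2-c2ccccc2)c1=N` gives 61% in this assay, and the only measured step, a number 61 percentage points lower from compound 1 to compound 2 (beyond the scatter), concerns a different change. Compound 3 `N=c1c2cc(-c3ccc(Br)cc3)n(-c3ccccc3)c2[nH]c(=S)n1N` differs from compound 2 by bromo in place of chloro on an aromatic carbon. Going by the values given here, no measured step touches a change of this kind, so nothing here points to a step beyond the scatter in this assay. Compound 3 is therefore expected to give about 5%, within the range 0% to 20%. This estimate means an expected step of a number 5 percentage points higher from compound 2 to compound 3 (within the scatter), inside the scatter.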

Compound 3, a percentage reported as inhibition, in the whole organism at one dose (the size of the read-out at that dose, not a potency): 33%
For compound 3 the middle estimate is 28 percentage points below the measured one, and the stated range ends below it.
By their numbers in this assay, from the lowest: compound 2; then compound 3; then compound 1.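

In this assay, the swap from 4-chlorophenyl to 4-bromophenyl gives a number 33 percentage points higher from compound 2 to compound 3 (beyond the scatter), so this place on the outer ring affects the read-out even though one halogen atom replaces another and the counted donors, acceptors and charge stay the same. It also shows that a compound with amino on the aromatic nitrogen can give a clear read-out. No available evidence explains the step. Still open, going by these compounds, is how fluoro, methyl or methoxy would read at this place, and whether bromo gives a similar step with ethyl in place of amino.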